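The compounds below may be only part of what the source reports. "The series", "measured", "known", "first", "only" and "open" are said of these compounds alone.

Compound 1 `Cc1[nH]n(-c2nc3cc(Cl)ccc3[nH]2)c(=O)c1Cc1ccccc1`: in an assay on isolated protein for inhibition of alpha-ketoglutarate-dependent dioxygenase alkB homolog 3 (Homo sapiens), read by polymerase chain reaction, with a stated time of 1 h (a higher number here means a weaker inhibitor, a lower number a stronger inhibitor), compound 1 gives 4500 nM.
Compound 2 `Cc1[nH]n(-c2nc3cc(C(C)(C)C)ccc3[nH]2)c(=O)c1Cc1ccccc1`: in this assay compound 2 gives 640 nM.

Compound 2 holds the lower of the two numbers; the single step shown, a 7.0-fold lower number from compound 1 to compound 2 (0.85 log units; beyond the scatter), separates it from compound 1. Compound 3 `Cc1[nH]n(-c2nc3cc(Br)ccc3[nH]2)c(=O)c1Cc1ccccc1` arises from compound 2 by bromo in place of tert-butyl on an aromatic carbon. Among the measured compounds shown here, only that measured step bears on this change, since it likewise exchanged a halogen and tert-butyl at the same place; with bromo entering, a move back toward compound 1 is expected, though probably not the whole way. Compound 3 is therefore estimated at 3000 nM in this assay, between 1000 nM and 9000 nM, an expected step of a 4.7-fold higher number from compound 2 to compound 3 (0.67 log units; beyond the scatter).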

Compound 3, half-maximal inhibitory concentration: 490 nM
The estimate for compound 3 lay 6.1-fold (0.79 log units) above the measured number; the measured number lies below the stated range.
By their numbers in this assay, from the lowest: compounds 3 and 2 (each within the scatter of the next); then compound 1.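

In this assay, the exchange at this aromatic carbon gives a 1.3-fold lower number from compound 2 to compound 3 (0.12 log units; within the scatter), so bromo, with its single heavy atom, cannot be told apart here from the four carbons of tert-butyl. The two halogens, however, do differ: the exchange of chloro for bromo gives a 9.2-fold lower number from compound 1 to compound 3 (0.96 log units; beyond the scatter), so the gain seen with tert-butyl does not depend on a group of that size. From the compounds shown here alone, how an amine, a methoxy group or a carboxylic acid would fare at this place remains open. Nothing available accounts for the gap between chloro and bromo.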